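This account rests on a few compounds, and the source may have more. Where it says the series, first, only, none or still open, it means among the compounds named here.

Measured compounds:
compound 1, `CN(C(=O)C(C)(C)C)c1ccc2[nH]c(-c3n[nH]c4ccccc34)cc2n1`, 4990 nM
compound 2, `CN(C(=O)c1ccc(Cl)cc1)c1ccc2[nH]c(-c3n[nH]c4ccccc34)cc2n1`, 450 nM
compound 3, `CN(C(=O)c1ccc(Br)cc1)c1ccc2[nH]c(-c3n[nH]c4ccccc34)cc2n1`, 1080 nM

In a functional assay on HL-60 cells (Homo sapiens) for antiproliferative activity, read by MTT assay, with a stated time of 72 h (a higher number here means a weaker inhibitor, a lower number a stronger inhibitor), compound 3 stands second highest of the three numbers. Its nearest neighbour is compound 2, with a 2.4-fold higher number from compound 2 to compound 3 (0.38 log units; beyond the scatter); the furthest is compound 1, with a 4.6-fold lower number from compound 1 to compound 3 (0.66 log units; beyond the scatter).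

Compound 4 is `COc1ccc(C(=O)N(C)c2ccc3[nH]c(-c4n[nH]c5ccccc45)cc3n2)cc1`. The change from compound 3 is methoxy in place of bromo on an aromatic carbon.

Going by the values given here, the only measured step touching this position is the swap of one group on the aromatic carbon, a 2.4-fold higher number from compound 2 to compound 3 (0.38 log units; beyond the scatter), a modest step. The other two steps, an 11-fold lower number from compound 1 to compound 2 (1.04 log units; beyond the scatter) and a 4.6-fold lower number from compound 1 to compound 3 (0.66 log units; beyond the scatter), concern the aryl in place of tert-butyl and bear only indirectly. Among the compounds with values here, no measured compound carries methoxy at this position, so the direction is open; a step of modest size in either direction in this assay, or none beyond the scatter, is the expectation. Compound 4 is therefore expected to give 800 nM, with a range from 250 nM to 2600 nM. The expected step of a 1.4-fold lower number from compound 3 to compound 4 (0.13 log units; within the scatter) is estimated to stay near the scatter.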

Compound 4, half-maximal inhibitory concentration: 3320 nM
Beside the measured number, compound 4's estimate is 4.2-fold (0.62 log units) below it; measured number above the stated range.
By their numbers in this assay, from the lowest: compound 2; then compound 3; then compounds 4 and 1 (each within the scatter of the next).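

In this assay, this aromatic carbon tolerates less change than the halogen pair suggested: methoxy in place of bromo gives a 3.1-fold higher number from compound 3 to compound 4 (0.49 log units; beyond the scatter) and methoxy in place of chloro gives a 7.4-fold higher number from compound 2 to compound 4 (0.87 log units; beyond the scatter) and both steps lie beyond the scatter. The gain from replacing tert-butyl therefore does not extend to every 4-substituted phenyl, since the step of a 1.5-fold lower number from compound 1 to compound 4 (0.18 log units; within the scatter) stays within the scatter, while the chloro and bromo analogues, compound 2 and compound 3, both differ from compound 1 beyond it. No measurement here accounts for the difference between methoxy and the halogens.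

Three substituents at this carbon give too little to define a trend across the series. Still open, as far as these compounds go, is how fluoro, an amine, a carboxylic acid or a longer alkoxy chain would behave at this carbon in the same assay.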